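A few compounds are considered here, and "the series" means these few. Any claim that something is new, unique, unknown or untested is made for them only; others in the source may bear on it.

Measured so far: compound 1 `COc1cccc(C(=O)N(C)c2ccc3[nH]c(-c4n[nH]c5ccccc45)cc3n2)c1` gives 14200 nM in a functional assay on HCT-116 cells (Homo sapiens) for antiproliferative activity, read by MTT assay, with a stated time of 72 h; on this read-out higher numbers stand for weaker inhibition and lower numbers for stronger inhibition; compound 2 `CN(c1ccc2[nH]c(-c3n[nH]c4ccccc34)cc2n1)S(=O)(=O)c1ccc(Br)cc1` gives 9850 nM in this assay.

Compound 2 gives the lower of the two numbers, but its step to compound 1 is within the scatter: a 1.4-fold lower number from compound 1 to compound 2 (0.16 log units; within the scatter). Compound 3 `CN(C(=O)Nc1ccccc1)c1ccc2[nH]c(-c3n[nH]c4ccccc34)cc2n1` differs from compound 2 by phenylcarbamoyl in place of (4-bromophenyl)sulfonyl on a nitrogen on an aromatic ring. Within the data shown here, the only measured step that bears on this change swaps a group on the same nitrogen, and it stayed within the scatter, so no step beyond the scatter is expected here. Compound 3 is therefore estimated at 11000 nM, within 4000 nM to 30000 nM, an expected step of a 1.1-fold higher number from compound 2 to compound 3 (0.05 log units; within the scatter).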

Compound 3, half-maximal inhibitory concentration: 1.3 nM
The estimate for compound 3 lay 8500-fold (3.93 log units) above the measured number; measured number below the stated range.
By their numbers in this assay, from the lowest: compound 3; then compounds 2 and 1 (each within the scatter of the next).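

In this assay, the group on this nitrogen proves decisive, though the earlier swap there showed no such effect: phenylcarbamoyl in place of (4-bromophenyl)sulfonyl gives a 7600-fold lower number from compound 2 to compound 3 (3.88 log units; beyond the scatter), and anilino in place of 3-methoxyphenyl on the carbonyl carbon gives an 11000-fold lower number from compound 1 to compound 3 (4.04 log units; beyond the scatter). Of the two groups compared in the first step, only phenylcarbamoyl counts a hydrogen-bond donor. No measurement here accounts for the jump.

As far as these compounds go, whether that hydrogen or the phenyl ring carries the gain stays open. So does whether a methylcarbamoyl group, with a methyl in place of the phenyl, would keep it.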